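The source may hold more compounds than are shown below. What is called first, only, known or untested is meant among the compounds shown, and "the series" means these compounds.

In a functional assay on HOS-TE85 cells (Homo sapiens) for inhibition, read by CCK-8 assay, with a stated time of 72 h (on this read-out higher numbers stand for weaker inhibition and lower numbers for stronger inhibition), compound 1, with structure `CC1SC(c2cccc(C(=O)NCCCCc3ccccc3)c2)N(c2ccc(C3CC3)cc2)C1=O`, gives 191 nM. Compound 2, with structure `O=C(NCCCCc1ccccc1)c1cccc(C2SCC(=O)N2c2ccc(-c3ccccc3)cc2)c1`, gives only a limit of the assay in this assay, > 1000 nM, so its inhibition is weaker than that number can resolve. Compound 3, with structure `O=C(NCCCc1ccccc1)c1cccc(C2SCC(=O)N2c2ccc(C3CC3)cc2)c1`, also gives only a limit in this assay, > 1000 nM. Compound 2 therefore stands at the limit of > 1000 nM in this assay, at which 2 of the 3 values shown sit, with no number of its own to compare with compound 1.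

Compound 4, with structure `COc1ccc(F)cc1N1C(=O)CSC1c1cccc(C(=O)NCCCCc2ccccc2)c1`, has not yet been measured. It differs from compound 2 in one place: 5-fluoro-2-methoxyphenyl in place of 4-phenylphenyl on an amide-type nitrogen in a ring. Going by the values given here, since compound 2 gives only a limit, no measured step sets the size of what this change does. Among the compounds with values here, the only numbered value comes from compound 1, whose cyclopropyl-bearing group on the same ring nitrogen gives 191 nM. The larger 4-phenylphenyl of compound 2, by contrast, reaches only a limit.

On that basis compound 4 is expected to fall between those two outcomes, with a step from an at least 1.6-fold lower number from compound 2 to compound 4 (0.22 log units; that floor lies within the scatter) that would be toward stronger inhibition, though a further limit cannot be ruled out. The estimate for compound 4 in this assay is 600 nM, within a range from 150 nM to 3000 nM.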

Compound 4, half-maximal inhibitory concentration: 8.8 nM
For compound 4 the middle estimate is 68-fold (1.83 log units) above the measured one; measured number below the stated range.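

In this assay, going by these compounds alone, placing 5-fluoro-2-methoxyphenyl in place of 4-phenylphenyl on the amide-type nitrogen in the ring gives an at least 110-fold lower number from compound 2 to compound 4 (2.05 log units; beyond the scatter), the first measured evidence that the group at this position can change the read-out strongly. This size is only a floor, because compound 2 has a limit and not a number of its own: the limit of > 1000 nM in this assay, at which 2 of the 4 values shown sit. The change also alters several things at once, replacing two six-membered aromatic rings with one, lowering the heavy-atom count, and bringing in an oxygen, a fluorine and one hydrogen-bond acceptor, so this single step shows that the exchange matters but not which of these differences is responsible.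

The compounds shown leave open whether the methoxy group, the fluorine or both are needed, which a phenyl group carrying only one of them would help to separate, and whether an amine or a hydroxyl group in place of the methoxy group would give a similar result. They also leave open whether the 5-fluoro-2-methoxyphenyl group would have the same effect with the chain of compound 3 or with the added methyl group of compound 1.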